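A few compounds are considered here, and "the series" means these few. Any claim that something is new, unique, unknown or untested is made for them only; others in the source may bear on it.

Measured in a functional assay on Jurkat cells (Homo sapiens) for inhibition, read by MTT assay, with a stated time of 72 h; a higher number here means a weaker inhibitor of growth, a lower number a stronger inhibitor of growth:
Compound 1 `CN(C)/C=N/c1c(C=O)c(-c2ccccc2)nn1-c1ccccc1` gives 23500 nM.
Compound 2 `CN(C)/C=N/c1c(C=O)c(-c2ccc(Cl)cc2)nn1-c1ccc(Br)cc1` gives 38900 nM.
Compound 3 `CN(C)/C=N/c1cc(-c2ccccc2)nn1-c1ccccc1` gives a limit of the assay, > 100000 nM.

Compound 1 and compound 2 lie within the usual scatter of each other, so neither can be set apart from the other. The value of compound 3 is a limit, not a number. Within the data shown here, the one measured step, an at least 4.2-fold higher number from compound 1 to compound 3 (0.62 log units; beyond the scatter), is the only change with a size attached, and it concerns the formyl group, which is kept in compound 4.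

Compound 4 `Nc1c(C=O)c(-c2ccccc2)nn1-c1ccccc1` differs from compound 1 by one nitrogen atom in place of a group of 5 heavy atoms (3 carbon, 2 nitrogen; no ring), on an aromatic carbon. Among the measured compounds shown here, no measured step touches this position, so there is nothing to show in which direction the number moves; compound 2 differs from compound 1 in two places at once and gives no guidance either. On that basis no step beyond the scatter is expected in this assay, and compound 4 is estimated at 30000 nM, with a range from 8000 nM to 100000 nM, which means an expected step of a 1.3-fold higher number from compound 1 to compound 4 (0.11 log units; within the scatter).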

Compound 4, concentration for 50% growth inhibition: 87300 nM
The estimate for compound 4 lay 2.9-fold (0.46 log units) below the measured number; low and high end bracket the measured number.
By their numbers in this assay, from the lowest: compounds 1 and 2 (each within the scatter of the next); then compound 4. At a limit, above all of these: compound 3.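

In this assay, the position on the aromatic carbon that bears the group of 5 heavy atoms proves sensitive to change: putting amino there gives a 3.7-fold higher number from compound 1 to compound 4 (0.57 log units; beyond the scatter). Earlier compounds left this position untouched, and this step shows that keeping the formyl group does not by itself preserve the number of compound 1, so the group at this position also counts. Among these compounds, nothing measured here explains the step, since the only supporting information concerns the assay limit reached by another compound.

Going by these compounds, it remains open whether a smaller substituted nitrogen group, such as methylamino or dimethylamino, or an acetamide would stay closer to compound 1 or to compound 4. The compounds shown also do not tell whether the same change would produce a similar step on the chlorophenyl and bromophenyl pattern of compound 2.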